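A few compounds are considered here, and "the series" means these few. Any claim that something is new, unique, unknown or untested is made for them only; others in the source may bear on it.

Working notes on the series.

The read-out throughout is a functional assay on HEK293 cells for agonist activity at Nucleotide-binding oligomerization domain-containing protein 1 (Homo sapiens), read by spectrophotometry; on this read-out lower numbers stand for an effect already at smaller amounts and higher numbers for an effect only at larger amounts of compound. Compound 1 `CCCCCCCCCCCC(=O)N[C@H](CCC(=O)NC(CCCC(NC(=N)N)C(=O)O)C(=O)O)C(=O)O` gives 0.622 nM. Compound 2 `CCCCCCCCCCCOC(=O)[C@@H](CCC(=O)NC(CCCC(N)C(=O)O)C(=O)O)NC(=N)N` gives 0.238 nM. Compound 3 `CCCCCCCCCCCOC(=O)CCCC(=O)NC(CCCC(N)C(=O)O)C(=O)O` gives 0.39 nM. Compound 1 and compound 3 lie within the usual scatter of each other; compound 1 and compound 2 lie beyond it, compound 2 carrying the lower number of the two.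

Going by the values given here, the one change carried out within measured compounds is a hydrogen atom in place of a group of 4 heavy atoms (1 carbon, 3 nitrogen; no ring), on a saturated chain carbon bound to a carbonyl carbon and a saturated chain carbon. It gives a 1.6-fold higher number from compound 2 to compound 3 (0.21 log units; within the scatter), so on this pair the removal of the group is not resolved from the scatter. The difference between the core of compound 1 and the core of compound 2 is not broken down here.

Compound 4 `CCCCCCCCCCCC(=O)N[C@H](CCC(=O)NC(CCCCC(=O)O)C(=O)O)C(=O)O` awaits measurement. It differs from compound 1 by a hydrogen atom in place of a group of 4 heavy atoms (1 carbon, 3 nitrogen; no ring), on a saturated chain carbon bound to a carbonyl carbon and a saturated chain carbon. The place description is the same word for word as in the change from compound 2 to compound 3, so the change is the same, carried out on the core of compound 1 instead of the core of compound 2.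

Expectation for compound 4: the step from compound 1 is estimated as a 1.6-fold higher number from compound 1 to compound 4 (0.21 log units; within the scatter), beside a 1.6-fold higher number from compound 2 to compound 3 (0.21 log units; within the scatter), because the one measured instance of this change, a 1.6-fold higher number from compound 2 to compound 3 (0.21 log units; within the scatter), stayed within the scatter. On that basis compound 4 is expected to give about 1 nM in this assay, estimated to fall between 0.4 nM and 2.5 nM. Among the compounds with values here, the single precedent rests on a different core, so the range is kept wide.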

Compound 4, half-maximal effective concentration: > 100 nM
Compound 4: no number, only a limit; the forecaster's own chance of this, stated with the estimate: 5%; middle value at least 100-fold (2.00 log units) from the limit.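

Compound 4 gives > 100 nM in this assay, and this is a limit of the assay, not a number. Loss of the group of 4 heavy atoms (1 carbon, 3 nitrogen; no ring) gives an at least 160-fold higher number from compound 1 to compound 4 (2.20 log units; beyond the scatter), so the near-silent result seen on the core of compound 2 does not carry over to the core of compound 1: the same change on two cores in this assay, a 1.6-fold higher number (0.21 log units; within the scatter) from compound 2 to compound 3 and an at least 160-fold higher number (2.20 log units; beyond the scatter) from compound 1 to compound 4, at least 98-fold (1.99 log units) apart, beyond the scatter of two such steps This comparison rests on a single pair per core, and the limit leaves the true size of the step on the core of compound 1 unfixed, so it shows neither the reason for the gap nor how the change would behave on any further core.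

The compounds shown leave open whether a hydroxyl group or a methyl group in that place, on a saturated chain carbon bound to a carbonyl carbon and a saturated chain carbon, would give a number close to that of compound 1 on the same core. Also open, as far as these compounds go, is whether a longer chain on the core of compound 1 would alter the size of the step seen there.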